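The compounds below may be only part of what the source reports. "The series", "measured", "known", "first", "only" and "open" are said of these compounds alone.

In a functional assay on SF-295 cells (Homo sapiens) for inhibition, read by sulforhodamine B assay, with a stated time of 48 h, tested at 0.1 uM (a lower number here means a stronger effect, a higher number a weaker effect of the compound at the concentration tested), compound 1 `O=C(Nc1cccc(-n2cc(-c3ccncc3)c(-c3cc(O)cc(Cl)c3)n2)c1)Nc1ccc(Cl)c(C(F)(F)F)c1` gives 93%, compound 2 `O=C(Nc1cccc(-n2cc(-c3ccncc3)c(-c3cc(O)cc(Cl)c3)n2)c1)Nc1ccc(Cl)c(Cl)c1` gives 87% and compound 3 `COc1cc(Cl)cc(-c2nn(-c3cccc(NC(=O)Nc4ccc(Cl)c(Cl)c4)c3)cc2-c2ccncc2)c1` gives 57%. The step of a number 6 percentage points lower from compound 1 to compound 2 (within the scatter) stays within the scatter; the step of a number 30 percentage points lower from compound 2 to compound 3 (beyond the scatter) is the only one beyond it, so compound 3 holds the lowest of the three numbers, below both compound 2 and compound 1. Compound 4 `COc1cc(Cl)cc(-c2nn(-c3cccc(NC(=O)c4cccc(C(F)(F)F)c4)c3)cc2-c2ccncc2)c1` differs from compound 3 by 3-(trifluoromethyl)phenyl in place of (3,4-dichlorophenyl)amino on a carbonyl carbon. Neither measured step touches the carbonyl carbon or its amide-type nitrogen, and the trifluoromethyl-for-chloro comparison sits on a different ring and stays within the scatter, so no basis exists for a directed step. In this assay the expected step is a number 6 percentage points higher from compound 3 to compound 4 (within the scatter), nothing beyond the scatter. Compound 4 is accordingly expected to give 63%, within 35% to 92%.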

Compound 4, a percentage reported as activity, at one concentration (the size of the read-out at that concentration, not a potency): 90%
Compound 4: middle estimate off by 27 percentage points, on the low side; the measured number falls inside the stated range.
By their numbers in this assay, from the lowest: compound 3; then compounds 2, 4 and 1 (each within the scatter of the next).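

In this assay, 3-(trifluoromethyl)phenyl in place of (3,4-dichlorophenyl)amino on the carbonyl carbon gives a number 33 percentage points higher from compound 3 to compound 4 (beyond the scatter), the first change shown at this position. The effect at the tested concentration therefore depends strongly on the group carried by this carbonyl carbon. The change swaps the amino nitrogen, with its hydrogen-bond donor, and the ring substituents together, and no measurement here accounts for the step.

Still open, as far as these compounds go, is whether the nitrogen or the ring substituents carry the step, which (3-(trifluoromethyl)phenyl)amino on the same carbon would address. A saturated amine such as morpholine at this position also remains untested in the compounds shown.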